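The source may hold more compounds than are shown below. What is called first, only, known or untested is meant among the compounds shown, and "the series" means these compounds.

Compound 1, `O=C(/C=C/c1ccc(O)cc1)c1c(O)cccc1OCC1CCCCC1`, is one of two compounds tested in a functional assay on NUGC-3 cells (Homo sapiens) for antiproliferative activity, read by sulforhodamine B assay; on this read-out higher numbers stand for weaker inhibition of growth and lower numbers for stronger inhibition of growth. In this assay compound 1 reports only a limit, > 30000 nM, and not a number. A second compound, compound 2, `CC(C)(C)CCOc1cccc(O)c1C(=O)CCc1ccc(O)cc1`, likewise gives only a limit in this assay, > 30000 nM. Among the measured compounds shown here, both values thus sit at the limit of > 30000 nM in this assay, at which 2 of the 2 values shown sit, so compound 1 stands no higher or lower than any other measured compound here: it is simply inactive within the range of the assay, and no step between measured compounds is available.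

The compound to be measured next is compound 3, `CC(C)CCCOc1cccc(O)c1C(=O)/C=C/c1ccc(O)cc1`. It differs from compound 1 in one place: isopentyl in place of cyclohexyl on a saturated chain carbon bound to an oxygen on an aromatic ring. The rest of the shared core, with its two phenolic hydroxyls and the unsaturated carbonyl linker, is unchanged.

With both measured values at the limit, no direction of change can be read from the data. The step from compound 1 to compound 3 is therefore expected to be a step that the limit leaves unreadable from compound 1 to compound 3, that is, none beyond the scatter. Compound 3 is expected to give about 40000 nM in this assay, within a range of 15000 nM to 120000 nM, most likely again as a limit rather than a number.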

Compound 3, concentration for 50% growth inhibition: 3520 nM
The estimate for compound 3 lay 11-fold (1.06 log units) above the measured number, and the stated range ends above it.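

In this assay, putting isopentyl in place of cyclohexyl on a saturated chain carbon bound to an oxygen on an aromatic ring gives an at least 8.5-fold lower number from compound 1 to compound 3 (0.93 log units; beyond the scatter), so this position is not indifferent to the group it carries. The earlier compounds could not show this, since compound 3 is the only one shown that gives a number and not a limit: the limit of > 30000 nM in this assay, at which 2 of the 3 values shown sit. The two groups have no hydrogen-bond donors or acceptors and no net charge, so on those counts they differ only in the ring and in their number of carbons, and the step is a bound and not a full measure of the change.

As far as these compounds go, a single pair cannot separate the loss of the ring from the shape or size of the open chain, so it remains open which of these matters. The compounds shown also leave open how a longer chain such as octyl, or an amine at the end of the chain, would fare in this assay on the core of compound 3.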